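Dimethylamide acrylamide on a naphthyl-pyridine: expected inhibition

A few compounds are considered here, and "the series" means these few. Any claim that something is new, unique, unknown or untested is made for them only; others in the source may bear on it.

Measured compounds:
- compound 1, `CNC(=O)/C=C/c1ccncc1-c1ccc2cccnc2c1`, 1760 nM
- compound 2, `NNC(=O)COc1ccncc1-c1ccc2ccccc2c1`, "not determined" (no result reported)
- compound 3, `O=C(/C=C/c1ccncc1-c1ccc2cccnc2c1)N1CCOCC1`, "not determined" (no result reported)

In an assay on a protein complex for inhibition of CDK8/Cyclin C (Homo sapiens), with a stated time of 1 h (on this read-out lower numbers stand for stronger inhibition and higher numbers for weaker inhibition), compound 1 gives 1760 nM. Compound 2 carries no number in this assay, and compound 3 likewise has none, so where compound 2 stands cannot be read from these figures. The new compound 4, `CN(C)C(=O)/C=C/c1ccncc1-c1ccc2ccccc2c1`, differs from compound 2 by 2-(dimethylcarbamoyl)ethenyl in place of (aminocarbamoyl)methoxy on an aromatic carbon. With no number for compound 2, the size and direction of this step in this assay cannot be anchored on compound 2 itself; the only measured point of reference is compound 1, which shares with compound 4 the ethenyl amide chain on the same core carbon but differs in the attached bicyclic ring. On that basis compound 4 is expected to land in the same broad region as compound 1, with wide uncertainty: the estimate is 3000 nM, in a range from 800 nM to 12000 nM.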

Compound 4, half-maximal inhibitory concentration: 30.1 nM
The estimate for compound 4 lay 100-fold (2.00 log units) above the measured number, and the stated range ends above it.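

No new step can be read for compound 4: compound 2 has no number to compare it with, and compound 1 differs from it in more than one place. The compounds shown leave open how much the 2-(dimethylcarbamoyl)ethenyl group itself contributes to the inhibition by compound 4. Nothing available here explains the result.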